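Swapping a Methyl for Fluorine on the Sulfone Aryl Ring

The compounds below may be only part of what the source reports. "The series", "measured", "known", "first", "only" and "open" are said of these compounds alone.

Three compounds sharing one core were examined in an ADME assay on microsomes from liver (Homo sapiens) for metabolic stability, read by LC-MS, with a stated time of 30 min, tested at 1 uM; on this read-out higher numbers stand for a more stable compound and lower numbers for a less stable compound. Compound 1, `Cc1cccc(S(=O)(=O)c2ccc(CNC(=O)c3cc4cnccc4[nH]3)cc2)c1`, gives 49%. Compound 2, `CC(NC(=O)c1cc2cnccc2[nH]1)c1ccc(S(=O)(=O)N2CCCCC2)cc1`, gives 34%, and compound 3, `O=C(NCc1ccc(S(=O)(=O)N2CCCCC2)cc1)c1ccc2nc[nH]c2c1`, gives 53%. Compound 1 thus lies clearly higher than compound 2, a gap beyond the usual scatter of such measurements, whereas compound 1 and compound 3 give numbers that cannot be told apart. Compound 4, `O=C(NCc1ccc(S(=O)(=O)c2cccc(F)c2)cc1)c1cc2cnccc2[nH]1`, has not yet been measured. It differs from compound 1 in one place only: fluoro in place of methyl on an aromatic carbon. Read one bond further out, the same difference turns a 3-methylphenyl into a 3-fluorophenyl. Among the compounds with values here, no pair of measured compounds here differs by this single change, so these numbers give no guide to the size of such a step. The step expected in this assay is therefore modest, a number 4 percentage points higher from compound 1 to compound 4 (within the scatter), not clearly beyond the scatter in either direction. For compound 4 the estimated value in this assay is 53%, within a range from 35% to 72%.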

Compound 4, percent of the compound remaining: 79%
The estimate for compound 4 lay 26 percentage points below the measured number; measured number above the stated range.
By their numbers in this assay, from the lowest: compound 2; then compounds 1 and 3 (each within the scatter of the next); then compound 4.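

In this assay, the step of a number 30 percentage points higher from compound 1 to compound 4 (beyond the scatter) comes from fluoro in place of methyl on an aromatic carbon. This shows that the read-out can respond clearly to a change of a single heavy atom at this place, even though no ring, hydrogen-bond donor, hydrogen-bond acceptor or net charge enters or leaves. It is also the first comparison here in which only one place differs, and no measurement shown explains why the number rises with the move from 3-methylphenyl to 3-fluorophenyl.

Still open, on these data alone, is whether another group at this place, such as chloro, methoxy, nitrile or an amine, would give a similar rise. A single pair also cannot tell whether the same swap would have a similar effect on a different core.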